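A few compounds are considered here, and "the series" means these few. Any claim that something is new, unique, unknown or untested is made for them only; others in the source may bear on it.

Measured so far, in an assay on a protein complex for positive allosteric modulation of Neuronal acetylcholine receptor; alpha4/beta2 (Homo sapiens); on this read-out higher numbers stand for larger maximal responses and lower numbers for smaller maximal responses:

Compound 1, `Cc1c(-c2cc(-c3ccccc3)no2)cnn1C1CCNCC1`: 31%
Compound 2, `Fc1ccc(-c2cc(-c3cnn(C4CCNCC4)c3)on2)c(Cl)c1`: 56%

Of these two numbers, compound 2 holds the higher one, and the gap to compound 1 lies beyond the usual scatter of this assay. Compound 3, `c1nn(C2CCNCC2)cc1-c1cc(C2CCCCC2)no1`, has not yet been measured. It differs from compound 2 in one place: cyclohexyl in place of 2-chloro-4-fluorophenyl on an aromatic carbon. An aromatic ring of carbon only, carrying a chlorine and a fluorine, gives way to a saturated ring of carbon only of the same ring size, at the same aromatic carbon next to the ring nitrogen.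

Among the measured compounds shown here, no pair of measured compounds shows what such a change does here, so the expectation rests on the two values alone. Compound 3 is expected to give a smaller maximal response than compound 2, with a step estimated at a number 21 percentage points lower from compound 2 to compound 3 (beyond the scatter) in this assay. The value for compound 3 is estimated at 35%, within a range from 15% to 60%.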

Compound 3, largest response reached (reported as efficacy), in percent of the reference or control that the assay uses: 16%
Estimate against measurement, compound 3: 19 percentage points above; low and high end bracket the measured number.
By their numbers in this assay, from the lowest: compound 3; then compound 1; then compound 2.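

In this assay, cyclohexyl in place of 2-chloro-4-fluorophenyl, on the aromatic carbon next to the ring nitrogen, gives a number 40 percentage points lower from compound 2 to compound 3 (beyond the scatter). This position is therefore sensitive to the group it carries: a saturated ring of carbon only, of the same ring size, does not keep the maximal response seen with the aromatic ring bearing chlorine and fluorine. Nothing measured here explains why the response changes.

As far as these compounds go, this single step replaces the aromatic ring and removes the chlorine and the fluorine all at once, so the share of each change in the result stays open. From the compounds shown here alone, how the response would change with an amine or a carboxylic acid at this position also remains unknown.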